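Ring oxygen count on the sulfonamide side chain

A few compounds are considered here, and "the series" means these few. Any claim that something is new, unique, unknown or untested is made for them only; others in the source may bear on it.

Compound 3 `NC(=O)[C@@H](CCC(F)(F)F)N(C[C@H]1CCCOC1)S(=O)(=O)c1ccc(Cl)cc1` gives 18.2 10^-6 cm/s in an ADME assay on MDCKII-LE cells (Canis lupus familiaris) for permeability, read by transwell migration, in the apical to basolateral direction; on this read-out lower numbers stand for lower permeability and higher numbers for higher permeability. Compound 1 `NC(=O)[C@@H](CCC(F)(F)F)N(C[C@H]1CCCCO1)S(=O)(=O)c1ccc(Cl)cc1` gives 13.4 10^-6 cm/s, and compound 2 `NC(=O)[C@@H](CCC(F)(F)F)N(C[C@@H]1CCCCO1)S(=O)(=O)c1ccc(Cl)cc1` gives 15.4 10^-6 cm/s; both steps to compound 3 are a 1.4-fold higher number from compound 1 to compound 3 (0.13 log units; within the scatter) and a 1.2-fold higher number from compound 2 to compound 3 (0.07 log units; within the scatter), so compound 3 sits within the scatter of both. The pair of compounds 1 and 2 differ only in configuration (the fact that compounds 1 and 2 differ only in the configuration as drawn), and that step is a 1.1-fold higher number from compound 1 to compound 2 (0.06 log units; within the scatter).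

Compound 4 `NC(=O)[C@@H](CCC(F)(F)F)N(C[C@@H]1COCCO1)S(=O)(=O)c1ccc(Cl)cc1` carries the change (1,4-dioxan-2-yl in place of oxan-3-yl on a saturated chain carbon bound to a sulfonamide nitrogen). For the measured compounds named here, no measured step in this set adds a second ring oxygen; the three steps at hand cover the point of attachment of the oxane ring and the configuration at its stereocentre, and each stayed within the scatter. On that basis a step in this assay of no more than the scatter is expected from compound 3 to compound 4, with the downward side slightly more open. The expected step is a 1.4-fold lower number from compound 3 to compound 4 (0.15 log units; within the scatter). Compound 4 is estimated at 13 10^-6 cm/s, with a range from 7 10^-6 cm/s to 24 10^-6 cm/s.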

Compound 4, apparent permeability: 27.3 10^-6 cm/s
For compound 4 the middle estimate is 2.1-fold (0.32 log units) below the measured one; the whole stated range lies below it.
By their numbers in this assay, from the lowest: compounds 1, 2, 3 and 4 (each within the scatter of the next, the first and the last beyond it).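

In this assay, 1,4-dioxan-2-yl in place of oxan-3-yl gives a 1.5-fold higher number from compound 3 to compound 4 (0.18 log units; within the scatter) and in place of oxan-2-yl gives a 1.8-fold higher number from compound 2 to compound 4 (0.25 log units; within the scatter) and a 2.0-fold higher number from compound 1 to compound 4 (0.31 log units; beyond the scatter) on the saturated chain carbon bound to a sulfonamide nitrogen. For the compounds shown here, the step from compound 1 is the first in the set to pass the scatter and is modest, while the steps from compound 2 and compound 3 go against any general rise with the second ring oxygen. The position thus accepts a second ring oxygen with no loss on this read-out, which the oxane compounds alone could not show.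

As far as these compounds go, whether this extends to a morpholin-2-yl group, with an amine in the ring, or to an open methoxyethyl chain stays open. Nothing shown bears on why the second ring oxygen goes with these numbers.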